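The source may report more compounds than this note shows. Statements on the series, on what has been measured and on what is new or still open speak of the compounds shown alone.

Compound 1 `Nc1ccccc1NC(=O)CCCNCC(=O)Nc1ccc(Cl)cc1`: > 100000 nM
Compound 2 `Nc1ccccc1NC(=O)CCCNCC(=O)Nc1cc(Cl)ccc1Cl`: > 100000 nM

Both entries come from a functional assay on U-251 cells (Homo sapiens) for inhibition, read by MTT assay, with a stated time of 2 days (on this read-out lower numbers stand for higher toxicity in this test and higher numbers for lower toxicity in this test), and neither is a number. In this assay compound 2 gives > 100000 nM, which is a limit of the assay. The same holds across the pair: the limit of > 100000 nM in this assay, at which 2 of the 2 values shown sit.

Compound 3 `Nc1ccccc1NC(=O)CCCNCC(=O)Nc1ccccc1Cl` follows from compound 2 by one change, hydrogen in place of chloro on an aromatic carbon, turning 2,5-dichlorophenyl into 2-chlorophenyl. Among the compounds with values here, one measured step bears on this, a step that the two limits leave unreadable from compound 1 to compound 2, and it offers no size to carry over. A step of definite size or direction in this assay is therefore not expected, and compound 3 will probably report a limit as well. The estimated step is a step that the limit leaves unreadable from compound 2 to compound 3, with no direction expected. For compound 3 the expected value is 120000 nM, with an estimated range from 50000 nM to 300000 nM.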

Compound 3, concentration lethal to 50% of the cells: > 100000 nM
Compound 3: no number, only a limit (the forecaster's own chance of this, stated with the estimate: 85%); the middle value lies beyond the limit too.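

In this assay compound 3 gives > 100000 nM, which is a limit of the assay. Within the data shown here, no step among compound 1, compound 2 and compound 3 can be read: the limit of > 100000 nM in this assay, at which 3 of the 3 values shown sit. The compounds shown leave open whether 4-chlorophenyl, 2,5-dichlorophenyl and 2-chlorophenyl differ at all in this assay.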